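A few compounds are considered here, and "the series" means these few. Any claim that something is new, unique, unknown or untested is made for them only; others in the source may bear on it.

Of the compounds shown here, two of a shared core have been measured in a functional assay on HOS-TE85 cells (Homo sapiens) for inhibition, read by CCK-8 assay, with a stated time of 72 h; a lower number here means a stronger inhibitor, a higher number a weaker inhibitor. Compound 1 `Cc1cccc(N2C(=O)CSC2c2cccc(C(=O)NCCCCc3ccccc3)c2)c1` gives 93.2 nM in this assay. Compound 2 `O=C(NCCCCn1cccn1)c1cccc(C2SCC(=O)N2c2ccccn2)c1` gives 60.3 nM in this assay, which is the lower of the two numbers, though the gap to compound 1 lies within the scatter, so the two cannot be placed in order. Compound 3 `O=C(NCCCCc1ccccc1)c1cccc(C2SCC(=O)N2c2ccccn2)c1` has not yet been measured. It differs from compound 2 in one place: phenyl in place of 1H-pyrazol-1-yl on a saturated chain carbon, four bonds along the chain from an amide-type nitrogen. Compound 1 carries the same phenyl on its chain but differs from compound 3 elsewhere, so its value offers only loose guidance. Among the measured compounds shown here, no step between measured compounds bears on this change, and the two measured values stand close together, so the expected step from compound 2 to compound 3 is a 1.2-fold higher number from compound 2 to compound 3 (0.09 log units; within the scatter), not beyond the scatter in either direction. Compound 3 is therefore estimated at 75 nM in this assay, with a range from 35 nM to 160 nM.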

Compound 3, half-maximal inhibitory concentration: 19.7 nM
The estimate for compound 3 lay 3.8-fold (0.58 log units) above the measured number; the whole stated range lies above it.
By their numbers in this assay, from the lowest: compound 3; then compounds 2 and 1 (each within the scatter of the next).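

In this assay the change from 1H-pyrazol-1-yl to phenyl on the chain gives a 3.1-fold lower number from compound 2 to compound 3 (0.49 log units; beyond the scatter), so the group at this place, four bonds along the chain from an amide-type nitrogen, does affect the read-out. With phenyl held constant on the chain, pyridin-2-yl in place of 3-methylphenyl on the amide-type nitrogen in a ring gives a 4.7-fold lower number from compound 1 to compound 3 (0.67 log units; beyond the scatter), showing that this second position also matters, which compound 1 and compound 2 could not show as they differ in more than one place. No evidence accompanies either step to account for it.

Among the compounds shown here, only two groups have been compared at the chain position, so it remains open how a substituted phenyl, a cyclohexyl ring or an amine would compare there. Also open, going by these compounds, is whether a shorter or longer chain would preserve the advantage of phenyl over 1H-pyrazol-1-yl.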